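Hydroxy to Methoxy on Compound 2

The source may hold more compounds than are shown below. What is called first, only, known or untested is meant among the compounds shown, and "the series" means these compounds.

Compound 1 `COc1cc(C=C(C(=O)/C=C/c2cccc(OC)c2OC)C(=O)/C=C/c2cccc(OC)c2OC)cc(Br)c1O` gives 220 nM
Compound 2 `COc1ccc(OC)c(/C=C/C(=O)C(=Cc2ccc(O)c(OC)c2)C(=O)/C=C/c2cc(OC)ccc2OC)c1` gives 340 nM

In a functional assay on CNE-2 cells (Homo sapiens) for antiproliferative activity, read by sulforhodamine B assay, with a stated time of 48 h (on this read-out higher numbers stand for weaker inhibition and lower numbers for stronger inhibition), compound 2 at 340 nM lies within the usual scatter of compound 1 at 220 nM so the two cannot be ranked. Compound 3 `COc1ccc(OC)c(/C=C/C(=O)C(=Cc2ccc(OC)c(OC)c2)C(=O)/C=C/c2cc(OC)ccc2OC)c1` changes compound 2 in one place: methyl in place of hydrogen on an oxygen on an aromatic ring with methyl in place of hydrogen on an oxygen on an aromatic ring. That turns 4-hydroxy-3-methoxyphenyl into 3,4-dimethoxyphenyl. Within the data shown here, no measured pair shows this change, so in this assay the expected 1.1-fold higher number from compound 2 to compound 3 (0.05 log units; within the scatter) stays within the scatter and has no firm direction. The estimated value for compound 3 is 380 nM with an expected range from 150 nM to 1000 nM as a cautious span.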

Compound 3, half-maximal inhibitory concentration: 550 nM
Beside the measured number, compound 3's estimate is 1.4-fold (0.16 log units) below it; measured number inside the range.
By their numbers in this assay, from the lowest: compounds 1, 2 and 3 (each within the scatter of the next, the first and the last beyond it).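

Among these compounds, replacing the hydrogen on this oxygen with methyl, which turns 4-hydroxy-3-methoxyphenyl into 3,4-dimethoxyphenyl, gives the first direct reading at this position. In this assay the change gives a 1.6-fold higher number from compound 2 to compound 3 (0.21 log units; within the scatter), so compound 2 and compound 3 cannot be ranked, and the free hydroxy is not shown to matter on this read-out. No supporting measurement bears on this result.

From the compounds shown here alone, it remains open whether a longer chain on this oxygen, such as ethyl or propyl, would also stay within the scatter. An amine in place of the hydroxy is equally untested among the compounds shown.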